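Adding Chloro to the Anilino Group of Compound 2

A few compounds are considered here, and "the series" means these few. Any claim that something is new, unique, unknown or untested is made for them only; others in the source may bear on it.

Two compounds have so far been run in an ADME assay on Huh-7 cells (Homo sapiens) for cytotoxicity, with a stated time of 3 days (a higher number here means that more compound is tolerated, a lower number that less compound is tolerated), and both reach the top of what the test can report. Compound 1 `Cc1cccc(NC(=O)c2c(NO)cc(-c3cccs3)oc2=O)c1` gives only a limit of the assay, not a number, namely > 20000 nM in this assay. Compound 2 `O=C(Nc1ccccc1)c1c(NCCO)cc(-c2cccc(Br)c2)oc1=O` likewise gives only a limit, > 20000 nM in this assay. Compound 2 therefore stands together with compound 1 at the limit of > 20000 nM in this assay, at which 2 of the 2 values shown sit, and nothing orders the two. Compound 3 `O=C(Nc1ccc(Cl)cc1)c1c(NCCO)cc(-c2cccc(Br)c2)oc1=O` is not yet measured; it differs from compound 2 by chloro in place of hydrogen on an aromatic carbon, in words chloro in place of hydrogen on an aromatic carbon. Among the compounds with values here, no measured pair shows what this change does here, so no step size can be drawn from the data. The expected step that the limit leaves unreadable from compound 2 to compound 3 is none beyond the scatter, with the reading most likely again a limit. Compound 3 is estimated at 30000 nM in this assay, within a range from 12000 nM to 80000 nM.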

Compound 3, half-maximal cytotoxic concentration: 17000 nM
For compound 3 the middle estimate is 1.8-fold (0.25 log units) above the measured one; the measured number falls inside the stated range.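

Within the data shown here, compound 3 is the first compound here to give a true number rather than a limit in this assay, which sets it apart from the others: the limit of > 20000 nM in this assay, at which 2 of the 3 values shown sit. Replacing anilino with (4-chlorophenyl)amino, which puts chloro in place of hydrogen on an aromatic carbon, gives an at least 1.1-fold lower number from compound 2 to compound 3 (0.07 log units; that floor lies within the scatter). Compound 2 has only a limit, so this step is a floor: the real difference could be larger or could vanish into the scatter, and the pair does not establish that chloro at this place lowers the amount of compound tolerated.

On these data alone, it remains open whether fluoro, methoxy or a carboxylic acid at the same place would give a number or another limit. Also open, as far as these compounds go, is whether chloro would have a similar effect in compound 1, whose other groups differ.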